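Demethylation of the ring amine in a bridged pyridyl series

This account rests on a few compounds, and the source may have more. Where it says the series, first, only, none or still open, it means among the compounds named here.

Measured so far:
compound 1, `CN1C[C@H]2C=C(c3cccnc3)C[C@H](C2)C1`: > 10000 nM
compound 2, `CN1CC2C=C(c3ccc(F)nc3)CC(C2)C1`: > 10000 nM
compound 3, `COc1cncc(C2=CC3CC(C2)CN(C)C3)c1`: 2660 nM

In an in vitro functional assay on SH-EP1 cells for agonist activity at Neuronal acetylcholine receptor; alpha4/beta2 (Homo sapiens), read by FLIPR and calcium flux (a lower number here means that less compound is needed, a higher number that more compound is needed for the effect), compound 1 gives > 10000 nM, which is a limit of the assay and not a measured number. Compound 2 also ends at a limit, > 10000 nM. Going by the values given here, compound 3 is the only one with a number, at 2660 nM. Compound 1 therefore stands at the limit of > 10000 nM in this assay, at which 2 of the 3 values shown sit, so its position relative to the others in this assay cannot be placed more closely than that.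

Among the compounds with values here, no pair of the measured compounds differs in a single place, so no measured step is available. The unmeasured compound 4, `C1=C(c2cccnc2)C[C@H]2CNC[C@@H]1C2`, differs from compound 1 in one place: hydrogen in place of methyl on an amine nitrogen in a ring. For this change the expectation is a step of moderate size in this assay, toward less compound needed, but the scatter of the assay and the fact that compound 1 rests at a limit leave that direction uncertain. Compound 4 is expected at 3000 nM, in the range 300 nM to 10000 nM, an expected step of an at least 3.3-fold lower number from compound 1 to compound 4 (0.52 log units; beyond the scatter).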

Compound 4, half-maximal effective concentration: 2.3 nM
Compound 4: middle estimate off by 1300-fold (3.12 log units), on the high side, and the stated range ends above it.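

In this assay, the amine nitrogen in the ring is a highly sensitive position in this pair: hydrogen in place of methyl gives an at least 4300-fold lower number from compound 1 to compound 4 (3.63 log units; beyond the scatter). The earlier compounds shown here all carry the methyl on this nitrogen, so they gave no view of this change. Compound 1 gives > 10000 nM, which is a limit of the assay and not a number, so the step has only a lower bound and its full size stays unknown: the limit of > 10000 nM in this assay, at which 2 of the 4 values shown sit.

Going by these compounds alone, only this one pair shows the change, so whether it carries over to the cores of compound 2 and compound 3 remains open. Also open is how an ethyl group or a longer chain on the same nitrogen would read, with hydrogen and methyl the only groups shown there.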